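Replacing the benzyl group on the ring nitrogen

A few compounds are considered here, and "the series" means these few. Any claim that something is new, unique, unknown or untested is made for them only; others in the source may bear on it.

Measured compounds:
compound 1 `NC(=O)c1c(NC(=O)c2ccccc2F)sc2c1CCN(Cc1cccc(Cl)c1)C2`: 23300 nM
compound 2 `NC(=O)c1c(NC(=O)c2ccccc2F)sc2c1CCN(Cc1ccc(Cl)cc1Cl)C2`: 9610 nM

Of the two compounds measured in a functional assay on MKN-74 cells (Homo sapiens) for antiproliferative activity, with a stated time of 24 h (on this read-out higher numbers stand for weaker inhibition and lower numbers for stronger inhibition), compound 2 gives the lower number, 9610 nM, while compound 1 gives 23300 nM. For the measured compounds named here, the only measured step is a 2.4-fold lower number from compound 1 to compound 2 (0.38 log units; beyond the scatter), and it concerns only the chlorine pattern on the benzyl ring.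

Compound 3 `NC(=O)c1c(NC(=O)c2ccccc2F)sc2c1CCN(C(=S)Nc1ccccc1Cl)C2` differs from compound 2 by a group of 10 heavy atoms (7 carbon, 1 nitrogen, 1 sulfur, 1 chlorine; one six-membered aromatic ring of carbon only) in place of a group of 9 heavy atoms (7 carbon, 2 chlorine; one six-membered aromatic ring of carbon only), on an amine nitrogen in a ring. Going by the values given here, no measured step bears on exchanging the whole benzyl group for the entering group; the one step available changed nothing but the chlorine positions and cannot be carried over. Among the compounds with values here, with no precedent, compound 3 is expected to land near compound 2, the estimated step being a 1.2-fold higher number from compound 2 to compound 3 (0.10 log units; within the scatter), with the direction uncertain and a wide spread. The estimate for compound 3 in this assay is 12000 nM, within a range from 3000 nM to 50000 nM.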

Compound 3, half-maximal inhibitory concentration: 11100 nM
For compound 3 the middle estimate is 1.1-fold (0.03 log units) above the measured one; measured number inside the range.
By their numbers in this assay, from the lowest: compounds 2 and 3 (each within the scatter of the next); then compound 1.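

In this assay, the group on the ring nitrogen can be exchanged as a whole, not merely altered in its chlorine pattern: a 1.2-fold higher number from compound 2 to compound 3 (0.06 log units; within the scatter), even though the entering group brings sulfur, nitrogen, a hydrogen-bond donor and a hydrogen-bond acceptor that 2,4-dichlorobenzyl lacks. The same kind of exchange starting from the 3-chlorobenzyl group gives a 2.1-fold lower number from compound 1 to compound 3 (0.32 log units; beyond the scatter), so among these compounds a benzyl group is not required on this amine nitrogen to reach the lower numbers. Nothing available explains why these different groups give such similar numbers.

As far as these compounds go, whether oxygen in place of the sulfur would give a similar number remains open. So does the outcome with a much smaller group on the ring nitrogen, such as methyl, or with a carboxylic acid on the entering ring.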